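Methylsulfonyl in place of a three-atom group on two cores

The source may report more compounds than this note shows. Statements on the series, on what has been measured and on what is new or still open speak of the compounds shown alone.

Compound 1 `Cn1c(-c2ccccc2)nnc1[S+](C)[O-]` and compound 2 `Cn1c(-c2ccccc2)nnc1S(C)(=O)=O` share one core. Compound 3 `Cn1nc(-c2ccccc2)nc1[S+](C)[O-]` is built from the same atoms as compound 1, joined differently; the difference between the two cores is not broken down here. Compound 4 `Cn1nc(-c2ccccc2)nc1S(C)(=O)=O` has not been measured.

In a functional assay on the whole organism for antagonist activity, with Mus musculus as the target (a lower number here means that less compound is needed, a higher number that more compound is needed for the effect), compound 1 gives > 100 mg/kg, which is a limit of the assay and not a number. In this assay compound 2 gives > 200 mg/kg, again a limit. In this assay compound 3 gives > 200 mg/kg, also a limit. The change from compound 1 to compound 2 is a group of 4 heavy atoms (1 carbon, 2 oxygen, 1 sulfur; no ring) in place of a group of 3 heavy atoms (1 carbon, 1 oxygen, 1 sulfur; no ring), on an aromatic carbon. The step it made, a step that the two limits leave unreadable from compound 1 to compound 2, cannot be read, since both values are limits. What the data offer on this step is the limit of > 100 mg/kg in this assay, at which 1 of the 3 values shown sits, and (the limit of > 200 mg/kg in this assay, at which 2 of the 3 values shown sit).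

Compound 4 differs from compound 3 by a group of 4 heavy atoms (1 carbon, 2 oxygen, 1 sulfur; no ring) in place of a group of 3 heavy atoms (1 carbon, 1 oxygen, 1 sulfur; no ring), on an aromatic carbon, the same change at a place described in the same words. No size can be carried over from the pair of compound 1 and compound 2, where the step is unreadable. All three measured values sit at limits, so compound 4 is expected to sit at a limit as well, most likely without a readable number. The step from compound 3 to compound 4 is estimated as a step that the limit leaves unreadable from compound 3 to compound 4, an expectation with wide uncertainty. Compound 4 is expected to give about 500 mg/kg, between 200 mg/kg and 2000 mg/kg.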

Compound 4, dose for half-maximal effect: > 200 mg/kg
Compound 4 gave a limit, no number (the forecaster's own chance of this, stated with the estimate: 85%); the middle value does not contradict the limit.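

In this assay compound 4 gives > 200 mg/kg, which is a limit of the assay and not a number. Compound 3 gives > 200 mg/kg, also a limit, so no step can be read from compound 3 to compound 4. The compounds shown leave open whether methylsulfonyl in place of the three-atom group changes the dose needed in this assay on either core.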